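This account rests on a few compounds, and the source may have more. Where it says the series, first, only, none or still open, it means among the compounds named here.

Measured in a functional assay (mast cells) for inhibition, with Rattus norvegicus as the target; a higher number here means that more compound is needed for the effect, a lower number that less compound is needed:
- Compound 1 `CC1CC/C(=N\Nc2cccc(Cl)c2)c2ncc(C(=O)O)c(=O)n21`: 311000 nM
- Compound 2 `CC1CC/C(=N\Nc2ccc(O)cc2)c2ncc(C(=O)O)c(=O)n21`: 1300 nM
- Compound 3 `Cc1cccc(N/N=C2\CCC(C)n3c2ncc(C(=O)O)c3=O)c1`: 72900 nM

Compound 2 stands lowest of the three, at 1300 nM. Compound 4 `CC1CC/C(=N\Nc2ccc([N+](=O)[O-])cc2)c2ncc(C(=O)O)c(=O)n21` has nitro in place of hydroxy on an aromatic carbon. Among the measured compounds shown here, no measured step makes this exact exchange, and no measured compound carries nitro. The closest evidence comes from the two steps that join the 4-hydroxyphenyl compound to the others. Both a 240-fold lower number from compound 1 to compound 2 (2.38 log units; beyond the scatter) and a 56-fold higher number from compound 2 to compound 3 (1.75 log units; beyond the scatter) are large, whereas a 4.3-fold lower number from compound 1 to compound 3 (0.63 log units; beyond the scatter) is modest. A sizeable step to a higher number is therefore expected in this assay. The expected change is a 12-fold higher number from compound 2 to compound 4 (1.06 log units; beyond the scatter). Compound 4 is estimated at 15000 nM, with an expected range of 2000 nM to 100000 nM.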

Compound 4, half-maximal effective concentration: 8900 nM
The estimate for compound 4 lay 1.7-fold (0.23 log units) above the measured number; measured number inside the range.
By their numbers in this assay, from the lowest: compound 2; then compound 4; then compound 3; then compound 1.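

In this assay, a 6.8-fold higher number from compound 2 to compound 4 (0.84 log units; beyond the scatter), the first exchange seen on the aromatic carbon para to a large group with nothing else altered. Hydroxy gives the lower number of the two, but the modest step shows that it is not the only group compatible with a number in this range. Nothing available here accounts for the size of this step. The compounds shown leave open whether an amine or a methoxy group at this same place would come closer to compound 2 or to compound 4.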